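Amide aryl replacement: from bromophenyl to hydroxyphenyl

The compounds below may be only part of what the source reports. "The series", "measured", "known", "first", "only" and "open" are said of these compounds alone.

Three amides of the shared core have numbers in a functional assay on A549 cells (Homo sapiens) for inhibition, read by CCK-8 assay, with a stated time of 72 h, tested at 10 uM; a higher number here means more inhibition of growth at the concentration tested, a lower number less inhibition of growth. Compound 1 `CN(C)C(=O)c1cc2cnc(Nc3ccc(NC(=O)C4(C(=O)Nc5ccccc5F)CC4)cc3)nc2n1C1CCCC1` gives 88.6%. Compound 2 `CN(C)C(=O)c1cc2cnc(Nc3ccc(NC(=O)C4(C(=O)Nc5ccc(Cl)c(C(F)(F)F)c5)CC4)cc3)nc2n1C1CCCC1` gives 88.1%. Compound 3 `CN(C)C(=O)c1cc2cnc(Nc3ccc(NC(=O)C4(C(=O)Nc5cccc(Br)c5)CC4)cc3)nc2n1C1CCCC1` gives 92.2%. Compound 3 holds the highest of the three numbers, but a number 3.6 percentage points higher from compound 1 to compound 3 (within the scatter) and a number 4.1 percentage points higher from compound 2 to compound 3 (within the scatter) both sit within the scatter, as does a number 0.5 percentage points lower from compound 1 to compound 2 (within the scatter), so the three compounds are not separated by this assay.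

Compound 4 `CN(C)C(=O)c1cc2cnc(Nc3ccc(NC(=O)C4(C(=O)Nc5ccc(O)cc5)CC4)cc3)nc2n1C1CCCC1` has not been measured. It differs from compound 3 at one place: 4-hydroxyphenyl in place of 3-bromophenyl on an amide-type nitrogen. All three measured steps change the aryl group on the same amide-type nitrogen, and all three stayed within the scatter, so the series gives no sign that this position moves the growth inhibition at the tested concentration. Going by the values given here, no measured step introduces a hydrogen-bond donor or acceptor at this place, so the bearing of the earlier steps on this one is indirect. The estimated step is a number 7.2 percentage points lower from compound 3 to compound 4 (within the scatter), which is expected to stay within the scatter. Compound 4 is therefore expected to give 85%, with a range from 65% to 95% in this assay.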

Compound 4, percent growth inhibition at one concentration: 94.4%
Estimate against measurement, compound 4: 9.4 percentage points below; measured number inside the range.
By their numbers in this assay, from the lowest: compounds 2, 1, 3 and 4 (each within the scatter of the next).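

Read in this assay the 4-hydroxyphenyl group is the first aryl group at this amide-type nitrogen to carry a hydrogen-bond donor and acceptor, and it stays level with all three halogen-bearing aryl groups (a number 2.2 percentage points higher from compound 3 to compound 4 (within the scatter); a number 6.3 percentage points higher from compound 2 to compound 4 (within the scatter); a number 5.8 percentage points higher from compound 1 to compound 4 (within the scatter)). Going by these compounds alone, with this result, all six steps among the four amides lie within the scatter, so at this one concentration the position accepts a hydroxyl-bearing aryl group as well as fluoro, bromo and chloro-trifluoromethyl ones, with no compound set apart from the others. No measurement given here explains why the number holds through this change.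

The compounds shown leave open how far this tolerance extends beyond substituted phenyl groups, for instance to a 4-aminophenyl, a 4-carboxyphenyl, a benzyl or a cyclohexyl group on the same nitrogen. They also leave open whether a 3-hydroxyphenyl group would read like the 4-hydroxyphenyl group, and whether these amides would separate at lower concentrations, which a single-concentration read-out cannot show.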